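Methoxy for chloro on the shared urea core

The source may report more compounds than this note shows. Statements on the series, on what has been measured and on what is new or still open speak of the compounds shown alone.

The series rests on a diarylurea. Compound 1 `Cc1ccc(NC(=O)Nc2cc(C)nc3ccccc23)cc1` gives 1300 nM in a physicochemical assay for solubility, at pH 7.4; on this read-out lower numbers stand for lower solubility and higher numbers for higher solubility. Compound 2 `Cc1cc(NC(=O)Nc2cccc(Cl)c2)c2ccccc2n1` gives 800 nM in this assay, the lowest of the two numbers, though the step of a 1.6-fold lower number from compound 1 to compound 2 (0.21 log units; within the scatter) lies within the scatter, so the two cannot be ordered. Compound 3 `COc1cccc(NC(=O)Nc2cc(C)nc3ccccc23)c1` is the next compound to be measured. It differs from compound 2 by methoxy in place of chloro on an aromatic carbon. For the measured compounds named here, none of the measured steps replaces a chloro with a methoxy; the one available step, from a 4-methylphenyl to a 3-chlorophenyl, was itself within the scatter, and it offers no direct guidance for this change. Going by the values given here, with only that step to go on, no movement beyond the scatter is expected from compound 2 to compound 3, so the step of a 1.3-fold higher number from compound 2 to compound 3 (0.10 log units; within the scatter) is estimated as small. Compound 3 is therefore estimated at 1000 nM in this assay, within a range of 400 nM to 2500 nM.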

Compound 3, solubility: 1200 nM
Compound 3: the middle estimate sits 1.2-fold (0.08 log units) below what was measured; measured number inside the range.
By their numbers in this assay, from the lowest: compounds 2, 3 and 1 (each within the scatter of the next).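

In this assay, for the compounds shown here, the first direct reading of this change gives a 1.5-fold higher number from compound 2 to compound 3 (0.18 log units; within the scatter) and so does not separate methoxy from chloro on this aromatic carbon, meta to a large group. The entering methoxy carries one more heavy atom and a hydrogen-bond acceptor that chloro lacks, yet the step stays within the scatter, as the earlier step from 4-methylphenyl to 3-chlorophenyl did. Nothing available accounts for the size of this step.

Going by these compounds, whether an amine or a carboxylic acid on this same aromatic carbon would give a step beyond the scatter remains open. Since both steps shown lie within the scatter, these compounds do not yet reveal whether any change at this position can move the number in this assay by more than repeat measurements would.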